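Series notes: pyrazolyl in place of tert-butoxy

This account rests on a few compounds, and the source may have more. Where it says the series, first, only, none or still open, it means among the compounds named here.

Two compounds of the shared core have numbers in a functional assay for inhibition of sodium/hydrogen exchanger (Oryctolagus cuniculus); on this read-out lower numbers stand for stronger inhibition and higher numbers for weaker inhibition. Compound 1 `Cc1cc(Br)c(S(C)(=O)=O)cc1C(=O)N=C(N)N` gives 12 nM. Compound 2 `Cc1cc(OC(C)(C)C)c(S(C)(=O)=O)cc1C(=O)N=C(N)N` gives 9.4 nM. The step of a 1.3-fold lower number from compound 1 to compound 2 (0.11 log units; within the scatter) shows that two quite different groups at this carbon leave the read-out essentially unchanged. Compound 2 stands with the lowest of the two numbers, but compound 1 is within the scatter of it, so no order between the two can be claimed.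

Compound 3 `Cc1cc(-n2cccn2)c(S(C)(=O)=O)cc1C(=O)N=C(N)N` is not yet measured. It differs from compound 2 by 1H-pyrazol-1-yl in place of tert-butoxy on an aromatic carbon. Among the measured compounds shown here, the only measured step at this carbon, from bromo to tert-butoxy, bears on it and was within the scatter; an aromatic ring with two hydrogen-bond acceptors at this place has no precedent among the measured compounds, so the range is kept wide. For compound 3 the expected number in this assay is 15 nM, with a range from 4 nM to 60 nM. That estimate means a step of a 1.6-fold higher number from compound 2 to compound 3 (0.20 log units; within the scatter), expected to stay within the scatter.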

Compound 3, half-maximal inhibitory concentration: 25 nM
For compound 3 the middle estimate is 1.7-fold (0.22 log units) below the measured one; low and high end bracket the measured number.
By their numbers in this assay, from the lowest: compounds 2 and 1 (each within the scatter of the next); then compound 3.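

In this assay, this aromatic carbon, ortho to a methylsulfonyl group, turns out not to be indifferent to its substituent: bromo and tert-butoxy could not be told apart, but 1H-pyrazol-1-yl separates from both. Putting 1H-pyrazol-1-yl in place of tert-butoxy gives a 2.7-fold higher number from compound 2 to compound 3 (0.42 log units; beyond the scatter) in this series, and putting it in place of bromo gives a 2.1-fold higher number from compound 1 to compound 3 (0.32 log units; beyond the scatter) on the same read-out, so both steps point the same way and both remain modest. Tert-butoxy and 1H-pyrazol-1-yl have the same heavy-atom count, so that count alone does not account for the step from one to the other, and no measurement at hand explains the difference.

Among the compounds shown here, with only three groups at this carbon, it remains open whether the higher number belongs to 1H-pyrazol-1-yl alone or extends to other aromatic rings, such as phenyl or an imidazole ring joined through nitrogen. Equally open, on these data alone, is where a non-aromatic group such as a dimethylamino group, a morpholine ring or a carboxylic acid would fall relative to compound 1, compound 2 and compound 3.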